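This account rests on a few compounds, and the source may have more. Where it says the series, first, only, none or still open, it means among the compounds named here.

Working notes on the series. Three compounds share one core. Compound 1 `CC1CCN(c2nc(C(F)(F)F)ccc2CNC(=O)C(C)c2cc(Cl)c(N)c(Cl)c2)CC1` carries an unsubstituted amino group on its ring and in an assay on cells for antagonist activity at transient receptor potential cation channel subfamily V member 1 (Homo sapiens), read by FLIPR and calcium flux, with a stated time of 6 min (on this read-out higher numbers stand for weaker inhibition and lower numbers for stronger inhibition), compound 1 gives 2.4 nM. Compound 2 `CC1CCN(c2nc(C(F)(F)F)ccc2CNC(=O)C(C)c2ccc(NC(=O)C(C)C)c(F)c2)CC1` carries an acylamino group instead, and in this assay compound 2 gives 26.4 nM. Compound 3 `CC1CCN(c2nc(C(F)(F)F)ccc2CNC(=O)C(C)c2ccc(NC(=O)C(C)(C)C)c(F)c2)CC1` carries the ((tert-butyl)carbonyl)amino group, and in this assay compound 3 gives 51.9 nM. Compound 3 thus stands at the high end of the three numbers: its gap to compound 2 lies within the scatter, its gap to compound 1 beyond it. Within the data shown here, the only measured one-place step, a 2.0-fold higher number from compound 2 to compound 3 (0.29 log units; within the scatter), adds a carbon on the acyl side and moves the number very little.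

Compound 4 `CC1CCN(c2nc(C(F)(F)F)ccc2CNC(=O)C(C)c2ccc(NC(=O)C3CC3)c(F)c2)CC1` differs from compound 3 by cyclopropyl in place of tert-butyl on a carbonyl carbon. The step of a 2.0-fold higher number from compound 2 to compound 3 (0.29 log units; within the scatter) is the closest guide, as it alters the same acyl group by one carbon and stays within the scatter; compound 1 differs in several places at once, so its value only marks how far this part of the series has moved. Removing one carbon and closing a ring on the carbonyl carbon is therefore expected to give, in this assay, a step of a 1.6-fold lower number from compound 3 to compound 4 (0.21 log units; within the scatter) that stays within the scatter, if anything toward a lower number. Compound 4 is estimated at 32 nM, with a range from 11 nM to 95 nM.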

Compound 4, inhibition constant: 20 nM
Compound 4: middle estimate off by 1.6-fold (0.20 log units), on the high side; the measured number falls inside the stated range.
By their numbers in this assay, from the lowest: compound 1; then compounds 4, 2 and 3 (each within the scatter of the next, the first and the last beyond it).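

Among these compounds, on the carbonyl carbon whose other neighbour is the amide-type nitrogen, cyclopropyl in place of tert-butyl gives in this assay a 2.6-fold lower number from compound 3 to compound 4 (0.41 log units; beyond the scatter) as a modest step, the first change to this acyl group that lies beyond the scatter. Cyclopropyl in place of isopropyl gives a 1.3-fold lower number from compound 2 to compound 4 (0.12 log units; within the scatter) and so cannot be separated from the isopropyl case, while a 2.0-fold higher number from compound 2 to compound 3 (0.29 log units; within the scatter) also stays within the scatter, which leaves tert-butyl distinguishable from cyclopropyl but not from isopropyl. Among these three acyl groups, the only readable difference is therefore the one between the two ends of the set, and no measurement at hand offers an explanation for it.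

On these data alone, whether this small spread holds for other groups on the same carbonyl carbon remains open, for example cyclobutyl, a longer chain such as n-butyl, or a methoxymethyl group. Compound 1 differs from the acylamino compounds in more than one place, so what separates its unsubstituted amino group from these acyl groups also remains unresolved.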